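Methoxy to Hydroxy on a Thiophene-Amide Series

The compounds below may be only part of what the source reports. "The series", "measured", "known", "first", "only" and "open" are said of these compounds alone.

This account concerns three measured compounds and one yet to be tested, all bearing a thiophenylmethyl group on an amide nitrogen. In an assay on HEK293 cells for agonist activity at transient receptor potential cation channel subfamily M member 8 (Homo sapiens), read by fluorescence and calcium flux, with a stated time of 15 min (on this read-out higher numbers stand for an effect only at larger amounts of compound and lower numbers for an effect already at smaller amounts), compound 1 `CCN(Cc1cccs1)C(=O)c1cc2cc(C)ccc2[nH]1` gives 2010 nM. Compound 2 `CON(Cc1cccs1)C(=O)COc1ccc(C)cc1` has an aryloxyacetyl group in place of the indole-type part of compound 1 and methoxy in place of the ethyl on nitrogen; in this assay compound 2 gives 10 nM, the lowest of the two reported numbers, and compound 1 stands well beyond the scatter above it. Compound 3 `CCN(Cc1cccs1)C(=O)c1cc2cc(C)ccc2n1C` carries a methyl on the ring nitrogen of the core of compound 1; in this assay compound 3 gives "not active" (no number reported), reported without a number.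

Compound 4 `Cc1ccc(OCC(=O)N(O)Cc2cccs2)cc1` differs from compound 2 in one place: hydrogen in place of methyl on an oxygen. Going by the values given here, no step between measured compounds of this kind is available, so the expectation rests on the position of compound 2 alone. Since the methoxy on nitrogen is part of what separates compound 2 from compound 1, the writer expects a modest upward shift, likely beyond the scatter, from compound 2 to compound 4, a 5.0-fold higher number from compound 2 to compound 4 (0.70 log units; beyond the scatter), in this assay. Compound 4 is therefore estimated at 50 nM in this assay, with a range from 10 nM to 300 nM.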

Compound 4, half-maximal effective concentration: 8000 nM
Beside the measured number, compound 4's estimate is 160-fold (2.20 log units) below it; the whole stated range lies below it.
By their numbers in this assay, from the lowest: compound 2; then compound 1; then compound 4.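

In this assay the change from methoxy to hydroxy gives an 800-fold higher number from compound 2 to compound 4 (2.90 log units; beyond the scatter), so the loss of one methyl from the oxygen on the amide-type nitrogen is enough on its own to produce a large step. The earlier compounds shown here could not show this: compound 1 and compound 2 differ in more than one place, so the gap between them could not be assigned to any single group, while compound 3 differs from compound 1 only on the ring nitrogen of the core. The compounds shown offer no measurement that explains why so small a change has so large an effect on this read-out.

As far as these compounds go, what remains open is how far this position tolerates anything other than methoxy: an ethoxy or a benzyloxy group on the same nitrogen could fall close to compound 2, close to compound 4 or elsewhere. From the compounds shown here alone, it is also open whether methoxy to hydroxy would give a step of similar size on another part of the series, such as the core of compound 1, or whether the size of this step holds only for the aryloxyacetyl compounds.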